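The source may hold more compounds than are shown below. What is called first, only, known or untested is meant among the compounds shown, and "the series" means these compounds.

Measured so far in a functional assay on T47D cells (Homo sapiens) for cytotoxicity, read by CCK-8 assay, with a stated time of 4 days; a higher number here means a weaker inhibitor, a lower number a stronger inhibitor:
compound 1, `Oc1cccc(-c2cc(-c3cccc(O)c3)nc(-c3ccccc3O)c2)c1`: 50000 nM
compound 2, `Oc1ccc(-c2cc(-c3cccc(O)c3)cc(-c3cccc(O)c3)n2)cc1`: 3920 nM
compound 3, `Oc1ccc(-c2cc(-c3cccc(O)c3)cc(-c3ccccc3O)n2)cc1`: 50000 nM

Compound 2 gives the lowest number of the three; the steps of a 13-fold lower number from compound 1 to compound 2 (1.11 log units; beyond the scatter) and a 13-fold higher number from compound 2 to compound 3 (1.11 log units; beyond the scatter) both lie beyond the scatter. The cores of compound 1 and compound 2 differ by 4-hydroxyphenyl in place of 2-hydroxyphenyl on an aromatic carbon. Compound 4, `Oc1ccc(-c2cc(-c3ccc(O)cc3)nc(-c3cccc(O)c3)c2)cc1`, is not yet measured; it differs from compound 2 by 4-hydroxyphenyl in place of 3-hydroxyphenyl on an aromatic carbon. The same kind of change was made from compound 1 to compound 3, (4-hydroxyphenyl in place of 3-hydroxyphenyl on an aromatic carbon), and gave no change at the digits printed from compound 1 to compound 3 (within the scatter). The surroundings are not identical: in that earlier pair the changed group sat next to the ring nitrogen, meta to a 2-hydroxyphenyl group and a 3-hydroxyphenyl group, whereas in the new pair it sits opposite the ring nitrogen, meta to a 3-hydroxyphenyl group and a 4-hydroxyphenyl group. On that basis, compound 4 is expected to show a step of a 1.1-fold lower number from compound 2 to compound 4 (0.05 log units; within the scatter) in this assay. Compound 4 is accordingly estimated at 3500 nM.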

Compound 4, half-maximal inhibitory concentration: 4470 nM
Compound 4: middle estimate off by 1.3-fold (0.11 log units), on the low side, within the range that was stated.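

In this assay, 4-hydroxyphenyl in place of 3-hydroxyphenyl, opposite the ring nitrogen, gives a 1.1-fold higher number from compound 2 to compound 4 (0.06 log units; within the scatter), and the same change on the other core agrees with it: the same change on two cores in this assay, no change at the digits printed (within the scatter) from compound 1 to compound 3 and a 1.1-fold higher number (0.06 log units; within the scatter) from compound 2 to compound 4, 1.1-fold (0.06 log units) apart, within the scatter of two such steps. Across these two pairs, the change therefore carries from one core to the other without a step beyond the scatter. This rests on two pairs only and does not show that the change stays silent on other cores, and the pair on the core of compound 1 stays at the higher end of the numbers printed.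

The compounds shown leave open what happens when a hydroxyphenyl group gives way to a methoxyphenyl, aminophenyl or carboxyphenyl group. They also leave open how any such group would behave at each place on the shared core.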